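Side-chain swap on the amide nitrogen: compound 1 to compound 3

The source may report more compounds than this note shows. Statements on the series, on what has been measured and on what is new or still open speak of the compounds shown alone.

Compound 1 (`Cc1cc(C#N)cc(C)c1Oc1nc(Nc2ccc(C#N)cc2)ncc1/C=C/C(=O)NCCOCCO`) gives > 200 nM in an ADME assay on TZM cells (Homo sapiens) for cytotoxicity, with a stated time of 1 days (on this read-out higher numbers stand for lower toxicity in this test and lower numbers for higher toxicity in this test), and this is a limit, not a number. Compound 2 (`Cc1cc(C#N)cc(C)c1Oc1nc(Nc2ccc(C#N)cc2)ncc1/C=C/C(=O)NC1CCN(S(C)(=O)=O)CC1`) gives > 175 nM in this assay, also a limit. Compound 3 (`Cc1cc(C#N)cc(C)c1Oc1nc(Nc2ccc(C#N)cc2)ncc1/C=C/C(=O)NCC1CCN(S(C)(=O)=O)C1`) keeps the core of compound 1 and carries 1-(methylsulfonyl)pyrrolidin-3-yl in place of (2-hydroxyethoxy)methyl on a saturated chain carbon bound to an amide-type nitrogen.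

Among the measured compounds shown here, only one measured step bears on this change: a step that the two limits leave unreadable from compound 1 to compound 2. That step also replaces the open chain with a ring carrying methylsulfonyl, but it has no readable size. On that evidence, no step beyond the usual scatter is expected in this assay, and no direction can be assigned. The estimated change is a number no higher from compound 1 to compound 3 (the limit leaves the size open). A report as a limit is expected again. For compound 3 the estimate is 200 nM, with an expected range of 150 nM to 600 nM.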

Compound 3, half-maximal cytotoxic concentration: > 175 nM
Compound 3 was reported as a limit; the forecaster's own chance of this, stated with the estimate: 85%; the middle value does not contradict the limit.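

In this assay, among the compounds shown here, compound 1, compound 2 and compound 3 all stand as limits, so no step among them can be read. Left open is where each compound's half-maximal cytotoxic concentration actually lies, and whether these side chains on the amide nitrogen differ at all on this read-out.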